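Thiosemicarbazones on a shared core: aryl ring variation

This account rests on a few compounds, and the source may have more. Where it says the series, first, only, none or still open, it means among the compounds named here.

Measured so far:
compound 1 `CC1=CC[C@H](C(C)(C)NC(=S)N/N=C/c2ccccc2)CC1` gives 5700 nM
compound 2 `COc1ccc(/C=N/NC(=S)NC(C)(C)[C@H]2CC=C(C)CC2)cc1` gives 1200 nM
compound 3 `CC1=CC[C@H](C(C)(C)NC(=S)N/N=C/c2cccc(Cl)c2)CC1` gives 6600 nM

In a functional assay on PC-3 cells (Homo sapiens) for inhibition, read by sulforhodamine B assay, with a stated time of 48 h (a higher number here means a weaker inhibitor of growth, a lower number a stronger inhibitor of growth), compound 1 stands second highest of the three numbers; the nearest is compound 3, with a 1.2-fold higher number from compound 1 to compound 3 (0.06 log units; within the scatter), and the furthest is compound 2, with a 4.8-fold lower number from compound 1 to compound 2 (0.68 log units; beyond the scatter). Compound 4 `CC1=CC[C@H](C(C)(C)NC(=S)N/N=C/c2ccc[nH]2)CC1` has not been measured. It differs from compound 1 in one place: 1H-pyrrol-2-yl in place of phenyl on a carbon with a double bond to nitrogen. Among the compounds with values here, no measured step swaps the whole ring; the steps to compounds 2 and 3 only decorate the phenyl, and the larger, a 4.8-fold lower number from compound 1 to compound 2 (0.68 log units; beyond the scatter), came from methoxy. With nothing that bears directly on this change, the expected step in this assay is none beyond the scatter, so compound 4 is estimated at 5000 nM (1500 nM to 15000 nM), which is a 1.1-fold lower number from compound 1 to compound 4 (0.06 log units; within the scatter).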

Compound 4, concentration for total growth inhibition: > 100000 nM
Compound 4 ended at the assay's limit; the forecaster's own chance of this, stated with the estimate: 10%; at least 20-fold (1.30 log units) between middle value and limit.
By their numbers in this assay, from the lowest: compound 2; then compounds 1 and 3 (each within the scatter of the next). At a limit, above all of these: compound 4.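

In this assay compound 4 stands at a limit of the assay, not at a number: the limit of > 100000 nM in this assay, at which 1 of the 4 values shown sits. Replacing the whole ring on this carbon with a double bond to nitrogen therefore matters far more than decorating the phenyl, with an at least 17-fold higher number from compound 1 to compound 4 (1.24 log units; beyond the scatter), an at least 15-fold higher number from compound 3 to compound 4 (1.18 log units; beyond the scatter) and an at least 83-fold higher number from compound 2 to compound 4 (1.92 log units; beyond the scatter). Growth inhibition at this position thus depends on the ring itself, not only on its substituents.

The compounds shown do not separate ring size from the hydrogen-bond donor that enters with 1H-pyrrol-2-yl. A pyridine or furan ring in the same place would bear on that question.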